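The compounds below may be only part of what the source reports. "The series", "measured", "known", "first", "only" and "open" are said of these compounds alone.

In an assay on brain for displacement of a labelled ligand from D(3) dopamine receptor (Rattus norvegicus) (a higher number here means a weaker inhibitor, a lower number a stronger inhibitor), the three measured compounds stand as follows:

Compound 1 `CCCN(CC[C@H]1CC[C@H](NS(=O)(=O)c2cccc3ccccc23)CC1)[C@H]1CCc2nc(N)sc2C1` gives 1.5 nM.
Compound 2 `CCCN(CC[C@H]1CC[C@H](NS(=O)(=O)c2ccc(-c3ccccc3)cc2)CC1)[C@H]1CCc2nc(N)sc2C1` gives 41 nM.
Compound 3 `CCCN(CC[C@H]1CC[C@H](NS(=O)(=O)c2cccc(C)c2)CC1)[C@H]1CCc2nc(N)sc2C1` gives 0.89 nM.

Compound 3 has the lowest number of the three. Its nearest neighbour is compound 1, and the step of a 1.7-fold lower number from compound 1 to compound 3 (0.23 log units; within the scatter) lies within the scatter, so the two cannot be ordered. Compound 2 is far off: the step of a 46-fold lower number from compound 2 to compound 3 (1.66 log units; beyond the scatter) is large and well beyond the scatter, and the step of a 27-fold higher number from compound 1 to compound 2 (1.44 log units; beyond the scatter) tells the same story from the other side.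

Compound 4 `CCCN(CC[C@H]1CC[C@H](NS(=O)(=O)c2ccc(C(C)C)cc2)CC1)[C@H]1CCc2nc(N)sc2C1` is not yet measured. It differs from compound 3 in one place: 4-isopropylphenyl in place of 3-methylphenyl on a sulfonyl sulfur. The measured steps that bear on this are the two that lead to compound 2, where a group on the same sulfonyl sulfur was replaced by 4-phenylphenyl and the number rose sharply. The group entering in compound 4 is smaller than 4-phenylphenyl, so a step of that full size is not expected, but some rise in this assay is plausible. For compound 4 the expected value is 5 nM, with a range from 1.5 nM to 20 nM. This corresponds to an estimated step of a 5.6-fold higher number from compound 3 to compound 4 (0.75 log units; beyond the scatter).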

Compound 4, inhibition constant: 4.5 nM
Compound 4: middle estimate off by 1.1-fold (0.05 log units), on the high side; low and high end bracket the measured number.
By their numbers in this assay, from the lowest: compounds 3 and 1 (each within the scatter of the next); then compound 4; then compound 2.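

In this assay, the step of a 5.1-fold higher number from compound 3 to compound 4 (0.70 log units; beyond the scatter) shows that the rise at the sulfonyl sulfur is not confined to 4-phenylphenyl: 4-isopropylphenyl also raises the number, although it keeps the single aromatic ring of the 3-methylphenyl it replaces. The step of a 9.1-fold lower number from compound 2 to compound 4 (0.96 log units; beyond the scatter), with isopropyl in place of phenyl on an aromatic carbon, shows that the change is graded, with compound 4 well short of the loss seen for compound 2, while the step of a 3.0-fold higher number from compound 1 to compound 4 (0.48 log units; beyond the scatter) places compound 4 clearly above the naphthalen-1-yl compound as well. Among these four compounds, the two groups with a substituent named at 4 on the phenyl ring, in compound 2 and compound 4, give higher numbers than 3-methylphenyl and naphthalen-1-yl, and no compound shown goes against this.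

Because 3-methylphenyl and 4-isopropylphenyl differ in both the substituent and its named position, the compounds shown leave open which of the two matters, and 4-methylphenyl or 3-isopropylphenyl would separate them. No measurement offered here accounts for the size of any of these steps.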